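From a thiophene-bearing aryl to an acyclic oxime ether

The source may hold more compounds than are shown below. What is called first, only, known or untested is meant among the compounds shown, and "the series" means these compounds.

Going by the values given here, compound 1 `Cc1ccsc1-c1ccccc1NCC1=NCCN1` gives 0.851 nM in a functional assay for activation of Alpha-1A adrenergic receptor (Homo sapiens), read by calcium flux (a higher number here means that more compound is needed for the effect, a lower number that less compound is needed), the lowest of the three numbers known. Compound 2 `Cc1cccnc1-c1ccccc1NCC1=NCCN1` gives 24.6 nM, and compound 3 `FC(F)(F)c1cccnc1-c1ccccc1NCC1=NCCN1` gives 676 nM, both beyond the scatter above compound 1. Among the compounds with values here, the single step between neighbours, a 27-fold higher number from compound 2 to compound 3 (1.44 log units; beyond the scatter), shows how sharply this assay responds to a change on an aromatic carbon of that side group. Compound 4 `CC/C(=N/OC)c1ccccc1NCC1=NCCN1` goes a different way: a group of 6 heavy atoms (4 carbon, 1 nitrogen, 1 oxygen; no ring) in place of a group of 6 heavy atoms (5 carbon, 1 sulfur; one five-membered aromatic ring with 1 hetero atom), on an aromatic carbon. Within the data shown here, no measured pair tests removal of the five-membered aromatic ring, so the expectation rests only on the sensitivity this assay shows to changes at that place. Compound 4 is expected to lose activity, with an estimated 30 nM (range 3 nM to 300 nM). That estimate means a 35-fold higher number from compound 1 to compound 4 (1.55 log units; beyond the scatter).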

Compound 4, half-maximal effective concentration: 87.1 nM
Beside the measured number, compound 4's estimate is 2.9-fold (0.46 log units) below it, and the stated range covers the measured number.
By their numbers in this assay, from the lowest: compound 1; then compound 2; then compound 4; then compound 3.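

In this assay, the acyclic oxime ether in place of 3-methylthiophen-2-yl gives a 100-fold higher number from compound 1 to compound 4 (2.01 log units; beyond the scatter) on the same core. This is the first pair among these compounds in which the group at this aromatic carbon has no ring, and compound 4 still gives a measurable value there, though at a far higher number. Nothing available explains this step. The compounds shown leave open whether the step follows from removing the ring or from the nitrogen and oxygen that enter, and how a phenyl ring or a plain butyl chain would read at this place.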